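Replacing the amino group of compound 2

This account rests on a few compounds, and the source may have more. Where it says the series, first, only, none or still open, it means among the compounds named here.

Measured so far in a physicochemical assay for solubility, in phosphate buffer, with a stated time of 18 h, at pH 7.4; on this read-out higher numbers stand for higher solubility and lower numbers for lower solubility:
- compound 1 (`Nc1cc2c(-n3nc(-c4ccccn4)nc3N)ncnc2cc1Cl`) gives 3000 nM
- compound 2 (`COc1cc2ncnc(-n3nc(-c4ccccn4)nc3N)c2cc1N`) gives 3000 nM
- compound 3 (`COc1cc2ncnc(-n3nc(-c4ccc(Cl)cc4)nc3N)c2cc1OC`) gives 1000 nM

Compound 2 stands level with compound 1 at the top of these three numbers, while compound 3 reads lower. Passing to compound 4 (`CCN(CC)C(=O)COc1cc2c(-n3nc(-c4ccccn4)nc3N)ncnc2cc1OC`) puts (diethylcarbamoyl)methoxy in place of amino on an aromatic carbon, ortho to a methoxy group ((diethylcarbamoyl)methoxy in place of amino on an aromatic carbon). Going by the values given here, the only measured step that differs in one place is no change at the digits printed from compound 1 to compound 2 (within the scatter) with methoxy in place of chloro, and it stays within the scatter. That step concerns another group, so no measurement speaks directly to the loss of the amino. Compound 3 differs from compound 2 in more than one place, and its number serves only as a loose guide to the low side. On this thin evidence, no step beyond the scatter is expected in this assay for this change. The estimated step is no change at the digits printed from compound 2 to compound 4 (within the scatter) with wide uncertainty. Compound 4 is estimated at 3000 nM within an expected range of 1000 nM to 10000 nM for now.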

Compound 4, solubility: 42000 nM
Beside the measured number, compound 4's estimate is 14-fold (1.15 log units) below it; measured number outside the range, above it.
By their numbers in this assay, from the lowest: compound 3; then compounds 1 and 2 (each within the scatter of the next); then compound 4.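

In this assay, putting (diethylcarbamoyl)methoxy in place of amino on this aromatic carbon, ortho to a methoxy group, gives a 14-fold higher number from compound 2 to compound 4 (1.15 log units; beyond the scatter), a large step beyond the scatter. The only earlier step between compounds that differ in one place, no change at the digits printed from compound 1 to compound 2 (within the scatter), concerned another group and stayed within the scatter, so this is the first sign among these compounds that the read-out can move far with a change in one place, and this position is where it does so. No measurement available here accounts for the rise.

Going by these compounds, the change swaps the amino group for the whole side chain at once, so it remains open whether the amide, the ether oxygen or the diethyl groups carry the step. A plain ethoxy group, a morpholine amide or a carboxylic acid on the same carbon would begin to separate these parts.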